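Glycolipid amide chain variants against colon carcinoma cells

The source may hold more compounds than are shown below. What is called first, only, known or untested is meant among the compounds shown, and "the series" means these compounds.

The series keeps the core of compound 1 `CCCCCCCCCCCCCCCCNC(=O)[C@H](O)CO[C@H]1O[C@H](CO)[C@@H](O)[C@H](O)[C@H]1NC(C)=O` and varies the lipid chain on the amide nitrogen. In a functional assay on HCT-116 cells (Homo sapiens) for cytotoxicity, read by sulforhodamine B assay, with a stated time of 72 h (on this read-out lower numbers stand for stronger inhibition and higher numbers for weaker inhibition), compound 1 gives only a limit, > 10000 nM. Compound 2 `CCCCCCCCCCCCCCCCCNC(=O)[C@H](O)CO[C@H]1O[C@H](CO)[C@@H](O)[C@H](O)[C@H]1NC(C)=O` likewise gives only a limit in this assay, > 10000 nM. The step that the two limits leave unreadable from compound 1 to compound 2 stays unreadable because both values sit at the limit of > 10000 nM in this assay, at which 2 of the 2 values shown sit. Compound 3 `CCCCCC/C=C\CCCCCCCCNC(=O)[C@H](O)CO[C@H]1O[C@H](CO)[C@@H](O)[C@H](O)[C@H]1NC(C)=O` brings the next change: a group of 8 heavy atoms (8 carbon; no ring) in place of a group of 9 heavy atoms (9 carbon; no ring), on a saturated chain carbon, eight bonds along the chain from an amide-type nitrogen. Among the compounds with values here, no measured step bears on it, and with compound 2 at the limit only a downward step could become visible. Compound 3 is expected to stay near the limit, with an estimated step that the limit leaves unreadable from compound 2 to compound 3. For compound 3 the estimate is 15000 nM (range 5000 nM to 60000 nM).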

Compound 3, half-maximal inhibitory concentration: > 10000 nM
Compound 3 ended at the assay's limit; the forecaster's own chance of this, stated with the estimate: 80%; the middle value lies beyond the limit too.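

No step can be read among compound 1, compound 2 and compound 3, as all three sit at the same limit: the limit of > 10000 nM in this assay, at which 3 of the 3 values shown sit.

In this assay, as far as these compounds go, it remains open whether any lipid chain on the shared core gives a value inside the limit.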